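The source may hold more compounds than are shown below. What is called first, only, known or untested is meant among the compounds shown, and "the series" means these compounds.

In a functional assay on CHO-K1 cells with Glucose-dependent insulinotropic receptor (Homo sapiens) as the target, read by a luciferase reporter, with a stated time of 5 h (on this read-out higher numbers stand for larger maximal responses and lower numbers for smaller maximal responses), compound 1 `CC(C)OC(=O)N1CCC(Oc2cccc3c2CCN3c2ccc(S(C)(=O)=O)cc2)CC1` gives 70%. Compound 2 `CCOC(=O)N1CCC(Oc2ncnc3c2CCN3c2ccc(S(C)(=O)=O)cc2F)CC1` gives 135% in this assay, the higher of the two numbers, standing beyond the scatter above compound 1. Compound 3 `CCSC(=O)N1CCC(Oc2ncnc3c2CCN3c2ccc(S(C)(=O)=O)cc2F)CC1` has not yet been measured; it differs from compound 2 by ethylsulfanyl in place of ethoxy on a carbonyl carbon. For the measured compounds named here, no measured pair shows this change, so its effect cannot be read from the numbers at hand. The step is expected to be small, a number 15 percentage points lower from compound 2 to compound 3 (beyond the scatter), with no direction that clearly exceeds the scatter. Compound 3 is therefore estimated at 120% in this assay, with a range from 90% to 150%.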

Compound 3, largest response reached (reported as percent of maximum), in percent of the reference or control that the assay uses: 128%
Compound 3: the middle estimate sits 8 percentage points below what was measured, within the range that was stated.
By their numbers in this assay, from the lowest: compound 1; then compounds 3 and 2 (each within the scatter of the next).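

In this assay, ethylsulfanyl in place of ethoxy on a carbonyl carbon gives a number 7 percentage points lower from compound 2 to compound 3 (within the scatter). For the compounds shown here, this is the first pair that differs in one place, and it shows that the maximal response at this position holds across this exchange of one heavy atom. Nothing at hand bears on why the response holds across this change. Open, on these data alone, is how a group of another kind on the same carbonyl carbon, such as an amine or a longer chain like butoxy, would read in this assay.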